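A few compounds are considered here, and "the series" means these few. Any claim that something is new, unique, unknown or untested is made for them only; others in the source may bear on it.

The compounds measured so far:
compound 1 `C=CC[C@@H]1O[C@@H]2CO[C@@H](c3ccccc3)O[C@H]2[C@H](OC)[C@H]1OC`: in a functional assay on HEL cells (Homo sapiens) for cytotoxicity (on this read-out higher numbers stand for lower toxicity in this test and lower numbers for higher toxicity in this test), compound 1 has "not determined" (no result reported).
compound 2 `CO[C@@H]1[C@@H](OC)[C@H](Cc2ccccc2)O[C@@H]2CO[C@@H](c3ccccc3)O[C@@H]12`: compound 2 gives > 50 ug/mL, which is a limit of this assay and not a number.
compound 3 `CO[C@@H]1[C@@H](OC)[C@H](c2ccccc2)O[C@@H]2CO[C@@H](C3CCCCC3)O[C@@H]12`: compound 3 gives 28 ug/mL.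

Going by the values given here, compound 3 thus stands as the only actual number among the three, with compound 2 sitting at the limit of > 50 ug/mL in this assay, at which 1 of the 3 values shown sits, and compound 1 without a result. Compound 4 `CO[C@@H]1[C@@H](OC)[C@H](c2ccccc2)O[C@@H]2CO[C@@H](c3ccc4ccccc4c3)O[C@@H]12` differs from compound 3 by naphthalen-2-yl in place of cyclohexyl on a saturated ring carbon. Among the compounds with values here, no pair of measured compounds isolates this change, so the step has no anchor; the account expects a step of a 1.1-fold lower number from compound 3 to compound 4 (0.05 log units; within the scatter) in this assay, small and within the usual scatter, with no clear direction. Compound 4 is therefore estimated at 25 ug/mL, in the range from 8 ug/mL to 60 ug/mL.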

Compound 4, half-maximal cytotoxic concentration: > 50 ug/mL
Compound 4 ended at the assay's limit (the forecaster's own chance of this, stated with the estimate: 20%); middle value at least 2.0-fold (0.30 log units) from the limit.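

On a saturated ring carbon between two ring oxygen atoms, naphthalen-2-yl in place of cyclohexyl gives, in this assay, an at least 1.7-fold higher number from compound 3 to compound 4 (0.25 log units; that floor lies within the scatter). From the compounds shown here alone, compound 4 gives > 50 ug/mL, which is a limit and not a number, so this position carries two aromatic rings with no lower number, but the true size of the step stays unknown. The read-out now often ends at this limit: the limit of > 50 ug/mL in this assay, at which 2 of the 4 values shown sit.

Going by these compounds, whether an amine or a carboxylic acid at this position would give a number under the limit stays open. Going by these compounds alone, with compound 3 still the only actual number, no trend across these groups can be read.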